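Toward a Methoxypyridine Ester in Place of the Chlorocinnamate

The source may report more compounds than this note shows. Statements on the series, on what has been measured and on what is new or still open speak of the compounds shown alone.

Among the compounds with values here, compound 3 `C=C1CC[C@@H]2[C@](C)(COC(=O)/C=C/c3cccc(Cl)c3)[C@H](O)CC[C@@]2(C)[C@@H]1/C=C/C1=CCOC1=O` is the one member of this set that yields a number in an ADME assay on HepG2 2.2.15 cells (Homo sapiens) for cytotoxicity, read by MTT assay; on this read-out higher numbers stand for lower toxicity in this test and lower numbers for higher toxicity in this test: compound 3 gives 147000 nM. Compound 1 `C=C1CC[C@@H]2[C@](C)(COC(=O)/C=C/c3cccc(OC)c3)[C@H](O)CC[C@@]2(C)[C@@H]1/C=C/C1=CCOC1=O` reaches only a limit of this assay, with > 1970000 nM. Compound 2 `C=C1CC[C@@H]2[C@](C)(COC(=O)/C=C/c3cc(OC)c(OC)c(OC)c3)[C@H](O)CC[C@@]2(C)[C@@H]1/C=C/C1=CCOC1=O` likewise stops at a limit, with > 1700000 nM. The two measured steps, an at least 13-fold lower number from compound 1 to compound 3 (1.12 log units; beyond the scatter) and an at least 11-fold lower number from compound 2 to compound 3 (1.06 log units; beyond the scatter), both run downward toward the chloro-bearing compound 3. Compound 4 `C=C1CC[C@@H]2[C@](C)(COC(=O)c3ccc(OC)nc3)[C@H](O)CC[C@@]2(C)[C@@H]1/C=C/C1=CCOC1=O` departs from compound 3 through (6-methoxypyridin-3-yl in place of 2-(3-chlorophenyl)ethenyl on a carbonyl carbon), giving up the chlorine and bringing in an aromatic methoxy group of the kind carried by compounds 1 and 2. Since both measured steps into compound 3 were large and downward, compound 4 is expected to move back upward, with a 10-fold higher number from compound 3 to compound 4 (1.01 log units; beyond the scatter) and an estimated 1500000 nM, spanning 300000 nM to 3000000 nM.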

Compound 4, half-maximal cytotoxic concentration: 1340000 nM
Compound 4: the middle estimate sits 1.1-fold (0.05 log units) above what was measured; low and high end bracket the measured number.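

In this assay, the whole 2-(3-chlorophenyl)ethenyl on the carbonyl carbon gives way to 6-methoxypyridin-3-yl, removing the chlorine and the chain double bond together, with a 9.1-fold higher number from compound 3 to compound 4 (0.96 log units; beyond the scatter). Compound 4 thus shows that a number this high does not require the ethenyl link carried by compounds 1 and 2. The comparison with compound 1 gives an at least 1.4-fold lower number from compound 1 to compound 4 (0.16 log units; that floor lies within the scatter), and it rests on a limit: the limit of > 1970000 nM in this assay, at which 1 of the 4 values shown sits.

The compounds shown leave open whether the chlorine or the ethenyl link carries the step from compound 3; a 6-chloropyridin-3-yl on the same carbonyl carbon would separate the two.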